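The source may hold more compounds than are shown below. What is called first, only, known or untested is meant among the compounds shown, and "the series" means these compounds.

Compound 1 `COc1ccc(C2C(C#N)=C(N)Oc3nc(Nc4ccc(S(N)(=O)=O)cc4)sc32)cc1`: 27500 nM
Compound 2 `COc1ccc(C2C(C#N)=C(/N=C/c3ccccc3)Oc3nc(Nc4ccc(S(N)(=O)=O)cc4)sc32)cc1`: 33600 nM
Compound 3 `COc1ccc(C2C(C#N)=C(/N=C/c3ccc([N+](=O)[O-])cc3)Oc3nc(Nc4ccc(S(N)(=O)=O)cc4)sc32)cc1`: 9700 nM

In a functional assay on MCF7 cells (Homo sapiens) for cytotoxicity, read by sulforhodamine B assay, with a stated time of 48 h (a lower number here means a stronger inhibitor, a higher number a weaker inhibitor), compound 2 holds the highest of the three numbers, though its gap to compound 1 is within the scatter. Compound 4 `COc1ccc(C2C(C#N)=C(/N=C/C=C/c3ccccc3)Oc3nc(Nc4ccc(S(N)(=O)=O)cc4)sc32)cc1` differs from compound 2 by 2-phenylethenyl in place of phenyl on a carbon with a double bond to nitrogen. For the measured compounds named here, no measured step alters the group on this carbon in the same way. The step that bears most closely is a 1.2-fold higher number from compound 1 to compound 2 (0.09 log units; within the scatter), in which the phenyl group itself entered and the number barely moved; the step of a 3.5-fold lower number from compound 2 to compound 3 (0.54 log units; beyond the scatter) concerns a nitro group that compound 4 does not carry. The step to compound 4 is therefore expected to stay within the scatter, a 1.1-fold lower number from compound 2 to compound 4 (0.05 log units; within the scatter). Compound 4 is estimated to give 30000 nM in this assay, with a range from 15000 nM to 60000 nM.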

Compound 4, half-maximal inhibitory concentration: 28900 nM
Estimate against measurement, compound 4: 1.0-fold (0.02 log units) above; low and high end bracket the measured number.
By their numbers in this assay, from the lowest: compound 3; then compounds 1, 4 and 2 (each within the scatter of the next).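

In this assay, 2-phenylethenyl in place of phenyl on this carbon leaves the number within the scatter (a 1.2-fold lower number from compound 2 to compound 4 (0.07 log units; within the scatter)), and compound 4 also stays within the scatter of the parent bearing the free nitrogen (a 1.1-fold higher number from compound 1 to compound 4 (0.02 log units; within the scatter)). Only 4-nitrophenyl stands apart from 2-phenylethenyl (a 3.0-fold higher number from compound 3 to compound 4 (0.47 log units; beyond the scatter)), so across these compounds the longer group alone does not go with a lower number. Nothing available explains this result.

Going by these compounds, whether an amine or a carboxylic acid in place of the nitro would keep the lower number remains open. So does whether nitro on the 2-phenylethenyl group would give it.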